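The source may hold more compounds than are shown below. What is called first, only, known or untested is meant among the compounds shown, and "the series" means these compounds.

Compound 1 `O=C(/C=C/c1ccc2c(c1)B(O)OC2)c1ccccc1`: 2300 nM
Compound 2 `O=C(/C=C/c1ccc2c(c1)B(O)OC2)c1ccc(Br)cc1`: 9500 nM
Compound 3 `CCc1ccc(C(=O)/C=C/c2ccc3c(c2)B(O)OC3)cc1`: 9800 nM

All three compounds were tested in a functional assay on MDA-MB-231 cells (Homo sapiens) for cytotoxicity, read by MTT assay, with a stated time of 48 h (a higher number here means a weaker inhibitor, a lower number a stronger inhibitor), and compound 1 gives the lowest of the three numbers, so it is the strongest inhibitor among them. Compound 4 `CCOC(=O)c1ccc(C(=O)/C=C/c2ccc3c(c2)B(O)OC3)cc1` is the next compound, not yet measured. It differs from compound 1 in one place: ethoxycarbonyl in place of hydrogen on an aromatic carbon.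

Among the measured compounds shown here, two measured steps bear on this change. Both also replace a hydrogen at the same position on the same ring of compound 1. Replacing that hydrogen with bromo gave a 4.1-fold higher number from compound 1 to compound 2 (0.62 log units; beyond the scatter), and replacing it with ethyl gave a 4.3-fold higher number from compound 1 to compound 3 (0.63 log units; beyond the scatter). The two substituted compounds land close together, since a 1.0-fold higher number from compound 2 to compound 3 (0.01 log units; within the scatter). Both steps point the same way: a group at this position weakens inhibition by a modest amount. Ethoxycarbonyl is a third such group, so a similar rise in the number is expected for compound 4, that is a 3.7-fold higher number from compound 1 to compound 4 (0.57 log units; beyond the scatter). Compound 4 is therefore estimated at 8500 nM, with a likely range from 3000 nM to 25000 nM.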

Compound 4, half-maximal inhibitory concentration: 13000 nM
Beside the measured number, compound 4's estimate is 1.5-fold (0.18 log units) below it; low and high end bracket the measured number.
By their numbers in this assay, from the lowest: compound 1; then compounds 2, 3 and 4 (each within the scatter of the next).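

A third group at this position again gives a higher number than hydrogen (a 5.7-fold higher number from compound 1 to compound 4 (0.75 log units; beyond the scatter)), so the loss seen with bromo and ethyl extends to ethoxycarbonyl, a larger group with hydrogen-bond acceptors. Ethoxycarbonyl also stands level with the other two groups (a 1.3-fold higher number from compound 3 to compound 4 (0.12 log units; within the scatter); a 1.4-fold higher number from compound 2 to compound 4 (0.14 log units; within the scatter)), so these three substituted compounds cannot be told apart, and the only readable difference at this position is between hydrogen and any of the three groups. No measurement shown here accounts for this pattern.

Going by these compounds, it remains open whether any group at this position could match or lower the number of compound 1, for example an amine, a hydroxyl or a carboxylic acid. The compounds shown also do not tell whether these three groups would behave alike at another place on the same ring.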